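Swapping the Side Arm: Expected Half-Life of Compound 4

The source may hold more compounds than are shown below. What is called first, only, known or untested is meant among the compounds shown, and "the series" means these compounds.

Compound 1, with the structure `CC1(C)NC(=O)N(CCC(COc2ccc(-c3ccc(C#N)cc3)cc2)N(O)C=O)C1=O`, is the longest-lived of the three measured compounds: in an in vivo ADME assay on the whole organism (Macaca fascicularis) for pharmacokinetics, at a dose of 3 mg/kg by the intravenous route (on this read-out higher numbers stand for a longer-lived compound and lower numbers for a shorter-lived compound), compound 1 gives 12.7 h. Compound 2, `N#Cc1ccc(-c2ccc(OCC(CN3C(=O)CCC3=O)N(O)C=O)cc2)cc1`, gives 0.6 h in this assay, and compound 3, `CCN1C(=O)N(CC(COc2ccc(-c3ccc(C#N)cc3)cc2)N(O)C=O)C(=O)C1(C)C`, gives 1.8 h. The step of a 21-fold lower number from compound 1 to compound 2 (1.33 log units; beyond the scatter) and the step of a 7.1-fold lower number from compound 1 to compound 3 (0.85 log units; beyond the scatter) both change the same side arm, on a saturated chain carbon, two bonds along the chain from an amide-type nitrogen, and both shorten the half-life.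

Compound 4, `Cc1ccc(=O)n(CC(COc2ccc(-c3ccc(C#N)cc3)cc2)N(O)C=O)n1`, is not yet measured. It differs from compound 1 by a group of 8 heavy atoms (5 carbon, 2 nitrogen, 1 oxygen; one six-membered aromatic ring with 2 hetero atoms) in place of a group of 10 heavy atoms (6 carbon, 2 nitrogen, 2 oxygen; one five-membered non-aromatic ring with 2 hetero atoms), on a saturated chain carbon, two bonds along the chain from an amide-type nitrogen. As in compounds 2 and 3, the five-membered non-aromatic ring and its methyl link are gone, replaced here by a six-membered aromatic ring with no hydrogen-bond donor. Because both measured changes at this place gave a 21-fold lower number from compound 1 to compound 2 (1.33 log units; beyond the scatter) and a 7.1-fold lower number from compound 1 to compound 3 (0.85 log units; beyond the scatter), a shorter half-life is expected for compound 4, a step of about a 6.4-fold lower number from compound 1 to compound 4 (0.80 log units; beyond the scatter). Compound 4 is therefore estimated to give 2 h in this assay, within a range from 0.7 h to 6 h.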

Compound 4, half-life: 0.5 h
Beside the measured number, compound 4's estimate is 4.0-fold (0.60 log units) above it, outside the stated range (below it).
By their numbers in this assay, from the lowest: compounds 4 and 2 (each within the scatter of the next); then compound 3; then compound 1.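

At this place, on a saturated chain carbon, two bonds along the chain from an amide-type nitrogen, the six-membered aromatic ring gives up nearly all of the half-life, with a 25-fold lower number from compound 1 to compound 4 (1.40 log units; beyond the scatter). It sits level with the 2,5-dioxopyrrolidin-1-yl group, showing a 1.2-fold lower number from compound 2 to compound 4 (0.08 log units; within the scatter), so two quite different rings end up together at the short end of this assay. The 3-ethyl-4,4-dimethyl-2,5-dioxoimidazolidin-1-yl group keeps more of the half-life, with a 3.6-fold lower number from compound 3 to compound 4 (0.56 log units; beyond the scatter).

Nothing available here explains why these changes shorten the half-life. Still open, as far as these compounds go, is whether a longer chain, holding the six-membered aromatic ring as the methyl link in compound 1 holds its ring, would bring the half-life back, or whether an amine or a carboxylic acid on that ring would shift it.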